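The source may report more compounds than this note shows. Statements on the series, on what has been measured and on what is new or still open speak of the compounds shown alone.

Compound 1 `COC(=O)CNC1=CS(=O)(=O)O[C@@]12[C@@H](CO[Si](C)(C)C(C)(C)C)O[C@@H](n1cc(C)c(=O)n(C)c1=O)[C@@H]2O[Si](C)(C)C(C)(C)C` carries a (methoxycarbonyl)methyl group on the amine nitrogen of the shared core. In a functional assay on CCRF-CEM cells (Homo sapiens) (on this read-out higher numbers stand for lower toxicity in this test and lower numbers for higher toxicity in this test), compound 1 gives 96000 nM, the highest number among the three measured compounds: compound 3 `COC(=O)CC(=O)NC1=CS(=O)(=O)O[C@@]12[C@@H](CO[Si](C)(C)C(C)(C)C)O[C@@H](n1cc(C)c(=O)n(C)c1=O)[C@@H]2O[Si](C)(C)C(C)(C)C` gives 29700 nM, and compound 2 `Cc1cn([C@@H]2O[C@H](CO[Si](C)(C)C(C)(C)C)[C@@]3(OS(=O)(=O)C=C3NC(N)=O)[C@H]2O[Si](C)(C)C(C)(C)C)c(=O)n(C)c1=O` gives 4360 nM. The step of a 3.2-fold lower number from compound 1 to compound 3 (0.51 log units; beyond the scatter) and the step of a 22-fold lower number from compound 1 to compound 2 (1.34 log units; beyond the scatter) both move the number downward, so every change made so far to this position has pushed this assay toward greater toxicity.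

Compound 4 `Cc1cn([C@@H]2O[C@H](CO[Si](C)(C)C(C)(C)C)[C@@]3(OS(=O)(=O)C=C3NCCC(=O)O)[C@H]2O[Si](C)(C)C(C)(C)C)c(=O)n(C)c1=O` differs from compound 1 in one place: carboxymethyl in place of methoxycarbonyl on a saturated chain carbon bound to an amine nitrogen. Within the data shown here, no measured pair changes an ester into an acid or lengthens this chain, so the two measured steps bear on it only loosely; they show that altering this side chain can shift this assay by a modest to large amount, without showing which way an acid would go.

The expectation is therefore a step of a 1.2-fold lower number from compound 1 to compound 4 (0.08 log units; within the scatter) that stays near or within the scatter. Compound 4 is estimated at 80000 nM, with a range from 25000 nM to 250000 nM.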

Compound 4, half-maximal cytotoxic concentration: 19400 nM
Compound 4: the middle estimate sits 4.1-fold (0.62 log units) above what was measured; the whole stated range lies above it.
By their numbers in this assay, from the lowest: compound 2; then compounds 4 and 3 (each within the scatter of the next); then compound 1.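

The acid-bearing 2-carboxyethyl chain also lowers the number in this assay (a 4.9-fold lower number from compound 1 to compound 4 (0.69 log units; beyond the scatter)), so all three other groups on the amine nitrogen of the shared core now give lower numbers, meaning more toxicity, than the (methoxycarbonyl)methyl group of compound 1. This chain still does not reach the number given by the carbamoyl group (a 4.4-fold higher number from compound 2 to compound 4 (0.65 log units; beyond the scatter)), and it cannot be told apart from the ((methoxycarbonyl)methyl)carbonyl group (a 1.5-fold lower number from compound 3 to compound 4 (0.18 log units; within the scatter)). Nothing available explains these shifts.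

On these data alone, compound 4 swaps the ester for a carboxylic acid and lengthens the chain at once, so the share of each change stays open. A carboxylic acid on the shorter chain of compound 1, or a methyl ester on the 2-carboxyethyl chain, would separate the two, while an amine at the chain end remains a further open case.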